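This account rests on a few compounds, and the source may have more. Where it says the series, first, only, none or still open, it means among the compounds named here.

Three compounds have been measured in an assay on ileum with muscarinic acetylcholine receptor M3 (Cavia porcellus) as the target; on this read-out lower numbers stand for stronger inhibition and higher numbers for weaker inhibition:

Compound 1 `CC(C)(C)c1nccn1CCC(C(N)=O)(c1ccccc1)c1ccccc1` gives 30.2 nM in this assay.
Compound 2 `Cc1ncn(CCC(C(N)=O)(c2ccccc2)c2ccccc2)c1C` gives 2.7 nM in this assay.
Compound 3 `CCc1ncn(CCC(C(N)=O)(c2ccccc2)c2ccccc2)c1CC` gives 3.98 nM in this assay.

Compound 3 stands second highest of the three numbers. Its nearest neighbour is compound 2, with a 1.5-fold higher number from compound 2 to compound 3 (0.17 log units; within the scatter), so the two cannot be told apart. Its furthest is compound 1, with a 7.6-fold lower number from compound 1 to compound 3 (0.88 log units; beyond the scatter); the related change gave an 11-fold lower number from compound 1 to compound 2 (1.05 log units; beyond the scatter). Among the compounds with values here, both of those steps exchange the whole group on the same chain carbon, so they show only that the group on that carbon matters, not how a ring fused onto it would behave.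

Compound 4 `NC(=O)C(CCn1cnc2ccccc21)(c1ccccc1)c1ccccc1` has not yet been measured. It differs from compound 3 in one place: 1H-benzimidazol-1-yl in place of 4,5-diethyl-1H-imidazol-1-yl on a saturated chain carbon, three bonds along the chain from two aromatic carbons and a carbonyl carbon. The entering group keeps the same count of heavy atoms and acceptors, but carries a six-membered aromatic ring of carbon only instead of two ethyl groups. Within the data shown here, no measured step maps onto this exchange, so the expectation rests on the observation that compounds 2 and 3 sit close together in this assay and that only compound 1 moved far from them. A small step is therefore expected, most likely toward a somewhat higher number, with wide uncertainty: compound 4 is expected at a 1.5-fold higher number from compound 3 to compound 4 (0.18 log units; within the scatter) relative to compound 3. The estimate for compound 4 in this assay is 6 nM, within 1.5 nM to 25 nM.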

Compound 4, antagonist equilibrium constant: 2130 nM
Compound 4: the middle estimate sits 360-fold (2.55 log units) below what was measured, outside the stated range (above it).
By their numbers in this assay, from the lowest: compounds 2 and 3 (each within the scatter of the next); then compound 1; then compound 4.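

Exchanging the two ethyl groups for a six-membered aromatic ring of carbon only leaves the counts of heavy atoms and acceptors unchanged, yet in this assay it gives a 540-fold higher number from compound 3 to compound 4 (2.73 log units; beyond the scatter) and, measured against the 4,5-dimethyl-1H-imidazol-1-yl group, a 790-fold higher number from compound 2 to compound 4 (2.90 log units; beyond the scatter) in the same direction. The 1H-benzimidazol-1-yl group also falls well behind the 2-(tert-butyl)-1H-imidazol-1-yl group, the poorest of the earlier groups, with a 71-fold higher number from compound 1 to compound 4 (1.85 log units; beyond the scatter) on the same saturated chain carbon, so matching counts of atoms do not make groups interchangeable at this position. Nothing available here explains why the number rises so steeply.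

As far as these compounds go, it remains open whether the loss follows from gaining the ring of carbon only or from losing the alkyl groups, and a plain 1H-imidazol-1-yl group, carrying neither, would help separate the two. From the compounds shown here alone, it is equally open whether this position needs an imidazole ring at all, a question that an open-chain dimethylamino group on the same carbon would address.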